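This account rests on a few compounds, and the source may have more. Where it says the series, first, only, none or still open, it means among the compounds named here.

Of the compounds shown here, three with a shared core have been measured in a functional assay on HT-29 cells (Homo sapiens) for antiproliferative activity, read by MTT assay, with a stated time of 72 h; a lower number here means a stronger inhibitor, a higher number a weaker inhibitor. Compound 1 `CCCNC(=O)c1cc(Oc2ccc(NC(=O)c3cc4cccnc4n(-c4ccc(Cl)cc4)c3=O)cc2)ccn1` gives 390 nM. Compound 2 `CCCNC(=O)c1cc(Oc2ccc(NC(=O)c3cc4cccnc4n(-c4ccc(Br)cc4)c3=O)cc2)ccn1`, in which bromo replaces chloro on an aromatic carbon, gives 530 nM; that step, a 1.4-fold higher number from compound 1 to compound 2 (0.13 log units; within the scatter), changes little. Compound 3 `CCCNC(=O)c1cc(Oc2ccc(NC(=O)c3cc4cccnc4n(-c4ccc(Br)cc4F)c3=O)cc2)ccn1` gives 2160 nM, the highest number of the three and thus the weakest inhibitor here, with a 4.1-fold higher number from compound 2 to compound 3 (0.61 log units; beyond the scatter) and a 5.5-fold higher number from compound 1 to compound 3 (0.74 log units; beyond the scatter) both clearly beyond the scatter.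

Compound 4 `CCCNC(=O)c1cc(Oc2ccc(NC(=O)c3cc4cccnc4n(-c4ccc(F)c(Cl)c4)c3=O)cc2)ccn1` has not yet been measured. It differs from compound 3 in one place: 3-chloro-4-fluorophenyl in place of 4-bromo-2-fluorophenyl on an aromatic nitrogen. Two of the measured steps bear on this. The swap of bromo for chloro, a 1.4-fold higher number from compound 1 to compound 2 (0.13 log units; within the scatter), was within the scatter, so exchanging these halogens alone should matter little. Adding a fluorine next to the ring nitrogen, a 4.1-fold higher number from compound 2 to compound 3 (0.61 log units; beyond the scatter), weakened inhibition; compound 4 keeps a fluorine but at a different position, so how much of that loss is undone cannot be read from these three compounds. Compound 4 is therefore expected to land between compound 3 and compound 2, a step of a 2.2-fold lower number from compound 3 to compound 4 (0.33 log units; beyond the scatter), at an estimated 1000 nM with a range from 400 nM to 2500 nM.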

Compound 4, half-maximal inhibitory concentration: 920 nM
Compound 4: middle estimate off by 1.1-fold (0.04 log units), on the high side; measured number inside the range.
By their numbers in this assay, from the lowest: compounds 1, 2 and 4 (each within the scatter of the next, the first and the last beyond it); then compound 3.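

The group on the aromatic nitrogen turns out to be sensitive to the arrangement of its halogens, not just to their presence: in this assay replacing 4-bromo-2-fluorophenyl with 3-chloro-4-fluorophenyl recovers part of the loss seen with compound 3 (a 2.3-fold lower number from compound 3 to compound 4 (0.37 log units; beyond the scatter)). A ring carrying fluorine is therefore not always as weak as compound 3, since compound 4 stays within the scatter of the 4-bromophenyl compound (a 1.7-fold higher number from compound 2 to compound 4 (0.24 log units; within the scatter)). It does not match the 4-chlorophenyl compound, however (a 2.4-fold higher number from compound 1 to compound 4 (0.37 log units; beyond the scatter)).

Nothing available explains why these arrangements differ. Also open, going by these compounds, is how this phenyl ring would respond to a methoxy group, an amine or a carboxylic acid in place of a halogen, and whether chloro and fluoro each contribute separately in compound 4.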